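This account rests on a few compounds, and the source may have more. Where it says the series, first, only, none or still open, it means among the compounds named here.

In a functional assay on Huh-7 cells (Homo sapiens) for antiproliferative activity, read by CCK-8 assay, with a stated time of 72 h (on this read-out lower numbers stand for stronger inhibition of growth and higher numbers for weaker inhibition of growth), compound 1 (`CCC1C(=O)N(C)c2cnc(Nc3ccc(S(=O)(=O)NC)cc3)nc2N1c1ccn(C)n1`) gives 11900 nM and compound 2 (`CC[C@@H]1C(=O)N(C)c2cnc(-n3ccc4cc(C(=O)NC)ccc43)nc2N1C1CCCC1`) gives 842 nM as the lower of the two numbers, a gap beyond the scatter. The change from compound 2 to compound 3 (`CC[C@@H]1C(=O)N(C)c2cnc(-n3ccc4cc(C(=O)NCC(C)C)ccc43)nc2N1C1CCCC1`) is isopropyl in place of hydrogen on a saturated chain carbon bound to an amide-type nitrogen. Going by the values given here, no measured pair shows this change, so no step beyond the scatter is expected in this assay and the estimate leans slightly toward weaker inhibition of growth, with a 1.4-fold higher number from compound 2 to compound 3 (0.15 log units; within the scatter) as the expected step. Compound 3 is expected at 1200 nM with an estimated range from 350 nM to 4000 nM as its likely span.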

Compound 3, concentration for 50% growth inhibition: "not active" (no number reported)
For compound 3 the study gives words and no number, so the estimate cannot be set against anything.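

Compound 3 is reported only in words, as not active, so no step from compound 2 can be read, and nothing shown bears on this result. The compounds shown leave open how far methylcarbamoyl to isobutylcarbamoyl shifts growth inhibition.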